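Swapping a dimethoxyphenyl for pyridyl in a hydrazone series

The compounds below may be only part of what the source reports. "The series", "measured", "known", "first", "only" and "open" are said of these compounds alone.

Measured compounds:
compound 1, `O=C(N/N=C/c1ccc(Cl)cc1)c1cccnc1Nc1cccc(C(F)(F)F)c1`, gives 48.5% in a functional assay on the whole organism (strain Wistar) for inhibition, with Rattus norvegicus as the target, read by paw edema, with a stated time of 3 h, at a dose of 10 mg/kg by the intraperitoneal route; on this read-out lower numbers stand for less inhibition and higher numbers for more inhibition at the one dose given (going by the name of the read-out).
compound 2, `COc1ccc(/C=N/NC(=O)c2cccnc2Nc2cccc(C(F)(F)F)c2)c(OC)c1`, gives 24.1%.
compound 3, `COc1ccc(/C=N/NC(=O)c2cccnc2Nc2cccc(C(F)(F)F)c2)cc1OC`, gives 44%.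

All three compounds share one core and differ only in the aromatic ring attached to the carbon with a double bond to nitrogen. Compound 3 stands second highest of the three numbers. Its nearest neighbour is compound 1, the gap being a number 4.5 percentage points lower from compound 1 to compound 3 (within the scatter). Its furthest is compound 2, the gap being a number 19.9 percentage points higher from compound 2 to compound 3 (beyond the scatter).

Compound 4, `O=C(N/N=C/c1ccncc1)c1cccnc1Nc1cccc(C(F)(F)F)c1`, has not yet been measured. It differs from compound 3 in one place: pyridin-4-yl in place of 3,4-dimethoxyphenyl on a carbon with a double bond to nitrogen.

The measured steps all concern the same ring position. The step of a number 24.4 percentage points lower from compound 1 to compound 2 (beyond the scatter) and the step of a number 19.9 percentage points higher from compound 2 to compound 3 (beyond the scatter) show that a change at this ring can move the read-out modestly in either direction, while a number 4.5 percentage points lower from compound 1 to compound 3 (within the scatter) shows that some changes there leave it unchanged. For the measured compounds named here, none of the measured steps involves pyridin-4-yl, so the direction cannot be read from them directly. A step of about a number 6 percentage points lower from compound 3 to compound 4 (within the scatter) is therefore expected, most likely within the scatter. Compound 4 is expected to give about 38%, in the range 18% to 58%.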

Compound 4, a percentage reported as inhibition, in the whole organism at one dose (the size of the read-out at that dose, not a potency): 54.9%
Compound 4: the middle estimate sits 16.9 percentage points below what was measured; the range from low to high includes it.
By their numbers in this assay, from the lowest: compound 2; then compounds 3, 1 and 4 (each within the scatter of the next, the first and the last beyond it).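

Replacing 3,4-dimethoxyphenyl with the smaller pyridin-4-yl, the only ring here with a nitrogen in it, gives in this assay a step that is a number 10.9 percentage points higher from compound 3 to compound 4 (beyond the scatter) and so shows that a nitrogen-containing ring is accepted at this position. Against the 2,4-dimethoxyphenyl ring the same group gives a number 30.8 percentage points higher from compound 2 to compound 4 (beyond the scatter) and this is the largest step in the set, whereas against 4-chlorophenyl it gives a number 6.4 percentage points higher from compound 1 to compound 4 (within the scatter) and the two rings cannot be told apart. The data hold nothing that explains why these rings differ.

As far as these compounds go, it stays open whether the placement of the ring nitrogen matters, which pyridin-3-yl or pyridin-2-yl would test, and whether plain phenyl would read like pyridin-4-yl or like the dimethoxyphenyl rings. A ring carrying an amine or a carboxylic acid would also extend the comparison, and since every value comes from one dose, the ranking says nothing about how these compounds would compare at other doses.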